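A few compounds are considered here, and "the series" means these few. Any claim that something is new, unique, unknown or untested is made for them only; others in the source may bear on it.

Three measured compounds share one core. In a functional assay on MGC-803 cells (Homo sapiens) for inhibition, read by MTT assay, with a stated time of 48 h (on this read-out lower numbers stand for stronger inhibition and higher numbers for weaker inhibition), compound 1 `CCC/C=C/C(=O)N(Cc1ccc(OC)c(O)c1)c1cc(OC)c(OC)c(OC)c1` gives 70 nM. Compound 2 `C/C=C/C=C/C(=O)N(Cc1ccc(OC)c(O)c1)c1cc(OC)c(OC)c(OC)c1` gives 140 nM in this assay, and compound 3 `COc1ccc(CN(C(=O)CCCl)c2cc(OC)c(OC)c(OC)c2)cc1O` gives 140 nM in this assay. Compound 3 stands level with compound 2 at the digits shown, with no change at the digits printed from compound 2 to compound 3 (within the scatter), and the third number lies close by, with a 2.0-fold higher number from compound 1 to compound 3 (0.30 log units; within the scatter). Compound 4 `COc1ccc(CN(C(=O)CBr)c2cc(OC)c(OC)c(OC)c2)cc1O` differs from compound 3 by bromo in place of chloromethyl on a saturated chain carbon bound to a carbonyl carbon. For the measured compounds named here, no measured step alters the group on that saturated chain carbon; the nearest comparisons are the two steps into compound 3, both within the scatter, so a step beyond the scatter is not expected here in this assay either. Compound 4 is therefore expected to give 140 nM in this assay, between 50 nM and 400 nM, which would be a step of no change at the digits printed from compound 3 to compound 4 (within the scatter).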

Compound 4, half-maximal inhibitory concentration: 140 nM
Compound 4: middle estimate and measured number agree at the digits printed; measured number inside the range.
By their numbers in this assay, from the lowest: compounds 1, 2, 3 and 4 (each within the scatter of the next).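

In this assay, for the compounds shown here, this is the first change at the saturated chain carbon bound to a carbonyl carbon: bromo in place of chloromethyl gives no change at the digits printed from compound 3 to compound 4 (within the scatter), so the chlorine and bromine compounds cannot be told apart. Bromomethyl on the carbonyl carbon also stays within the scatter of both unsaturated chains, with no change at the digits printed from compound 2 to compound 4 (within the scatter) and a 2.0-fold higher number from compound 1 to compound 4 (0.30 log units; within the scatter) in this comparison. No evidence is available on why these numbers fall as they do. The compounds shown leave open whether an amine, a carboxylic acid or a longer chain on that carbonyl carbon would stay within this range.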